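Swapping the methoxy of compound 2 for hydrogen

The source may hold more compounds than are shown below. What is called first, only, known or untested is meant among the compounds shown, and "the series" means these compounds.

Measured so far in an ADME assay on L1210/0 cells (Mus musculus) for cytotoxicity, with a stated time of 48 h (a lower number here means a stronger inhibitor, a higher number a weaker inhibitor), are two compounds:
compound 1 `CO[C@@H]1OC(n2cc(F)c(=O)[nH]c2=O)[C@H](OC(C)=O)[C@@H](OC(C)=O)[C@H]1F` gives 34000 nM
compound 2 `COc1ccccc1C(=O)/C=C/c1cc(=O)[nH]c(=O)n1COCCO` gives 15200 nM

Compound 2 holds the lower of these two numbers, which makes it the stronger inhibitor of the pair, and its gap to compound 1 lies beyond the usual scatter. The next compound is compound 3 `O=C(/C=C/c1cc(=O)[nH]c(=O)n1COCCO)c1ccccc1`, which differs from compound 2 in one place. It carries hydrogen in place of methoxy on an aromatic carbon, ortho to a large group (hydrogen in place of methoxy on an aromatic carbon), so that 2-methoxyphenyl becomes phenyl. For the measured compounds named here, no two measured compounds differ in one place only, so nothing yet shows what a swap like this does in this assay and the forecast stays cautious. No step beyond the scatter is expected, in either direction, though the range has to stay wide. The expected change is a 1.2-fold higher number from compound 2 to compound 3 (0.07 log units; within the scatter) and it is only an estimate. For compound 3 the estimated value is 18000 nM with an expected range from 7000 nM to 45000 nM in this measurement.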

Compound 3, half-maximal inhibitory concentration: 43300 nM
The estimate for compound 3 lay 2.4-fold (0.38 log units) below the measured number, within the range that was stated.
By their numbers in this assay, from the lowest: compound 2; then compounds 1 and 3 (each within the scatter of the next).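

In this assay the loss of the methoxy from this aromatic carbon gives a 2.8-fold higher number from compound 2 to compound 3 (0.45 log units; beyond the scatter) and so shows that this place on the ring is not indifferent: in this pair, the compound with 2-methoxyphenyl is the stronger inhibitor and the one with plain phenyl the weaker. This is the first comparison among the compounds shown in which only one place differs, and it gives the methoxy a real but modest share in the number, resting on this single pair alone. The data shown offer no measured explanation for the shift.

On these data alone, what stays open is whether the methoxy itself matters or whether other groups on the same carbon would hold the number as well; a hydroxyl, a fluorine atom or the longer ethoxy chain would each test this in turn. As far as these compounds go, it is also open whether this step would be the same size on a different core, or whether a methoxy on another carbon of the ring would give a similar number.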